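A few compounds are considered here, and "the series" means these few. Any claim that something is new, unique, unknown or untested is made for them only; others in the source may bear on it.

Measured so far:
compound 1 `CC(=O)OC[C@H]1O[C@H](OC[C@@H](Cn2cc(CN(c3nc(-c4ccc(Cl)cc4)no3)C3CCCCC3)nn2)OC(C)=O)C=C[C@@H]1OC(C)=O` — 35.5 ug/mL
compound 2 `C#CCN(c1nc(-c2cccc([N+](=O)[O-])c2)no1)C1CCCCC1` — 34.2 ug/mL
compound 3 `C#CCN(c1nc(-c2ccc(Br)cc2)no1)C1CCCCC1` — 15.7 ug/mL

All three values come from an ADME assay on RAW264.7 cells (Mus musculus) for cytotoxicity, read by MTT assay, with a stated time of 48 h; on this read-out higher numbers stand for lower toxicity in this test and lower numbers for higher toxicity in this test. Compound 1 holds the highest of the three numbers; compound 2 sits within the scatter of it, while compound 3 lies beyond the scatter at a lower number. For the measured compounds named here, no two measured compounds differ in one place, so no single-change comparison is available within this set.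

Compound 4 `CC(=O)OC[C@H]1O[C@H](OC[C@@H](Cn2cc(CN(c3nc(-c4ccc(F)cc4)no3)C3CCCCC3)nn2)OC(C)=O)C=C[C@@H]1OC(C)=O` is not yet measured in this assay. It differs from compound 1 by fluoro in place of chloro on an aromatic carbon. Going by the values given here, with no comparable step among the measured compounds, the expectation rests on compound 1 at 35.5 ug/mL and on the small size of the change. The expected step is a 1.1-fold lower number from compound 1 to compound 4 (0.05 log units; within the scatter), none beyond the scatter. Compound 4 is estimated at 32 ug/mL, within 16 ug/mL to 64 ug/mL.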

Compound 4, half-maximal cytotoxic concentration: 31.5 ug/mL
Compound 4: middle estimate off by 1.0-fold (0.01 log units), on the high side; the range from low to high includes it.
By their numbers in this assay, from the lowest: compounds 3, 4, 2 and 1 (each within the scatter of the next, the first and the last beyond it).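

In this assay this pair gives the series its first single-change comparison: fluoro in place of chloro on this aromatic carbon, para to a large group, is a step of a 1.1-fold lower number from compound 1 to compound 4 (0.05 log units; within the scatter) and leaves the number within the scatter. The 4-chlorophenyl and 4-fluorophenyl compounds therefore cannot be told apart on this read-out. Nothing measured here speaks to the reason for this. Still open, going by these compounds, is whether an amine or a carboxylic acid at this carbon would move the number beyond the scatter.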